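Capping the Hydroxyl: Will the Half-Life Hold?

The source may hold more compounds than are shown below. What is called first, only, known or untested is meant among the compounds shown, and "the series" means these compounds.

Compound 1 `C=C(CO)C(=O)Nc1ccccc1` was tested in an ADME assay for pharmacokinetics, read by LC-MS, in phosphate buffer, with a stated time of 120 min, at pH 7.4, tested at 1 uM, in the presence of a further agent that is not named here (a higher number here means that the compound lasts longer, a lower number that the compound disappears faster), and came back as > 8.53 h, which is a limit of the assay rather than a measured number. Two related compounds sharing the same core were run alongside it. Compound 2 `O=C(/C=C/CN1CCCC1)Nc1ccccc1` gave 2.7 h in this assay. Compound 3 `CN1CCN(C/C=C/C(=O)Nc2ccccc2)CC1` gave > 8.53 h in this assay, again a limit and not a number. Compound 1 therefore stands at the limit of > 8.53 h in this assay, at which 2 of the 3 values shown sit, with only compound 2 returning an actual figure.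

Compound 4 `C=C(COC)C(=O)Nc1ccccc1` has not yet been measured. It differs from compound 1 in one place: methyl in place of hydrogen on an oxygen on a saturated carbon. Among the compounds with values here, no pair of measured compounds in this set makes that same change, so there is no direct guide to its effect. The step from compound 1 to compound 4 is expected to be a number no higher from compound 1 to compound 4 (the limit leaves the size open), that is, nothing beyond the usual scatter, given that compound 1 already sits at the limit of > 8.53 h in this assay, at which 2 of the 3 values shown sit. Compound 4 is thus estimated at 8.5 h, within a range of 4 h to 17 h, and the assay may well report only its limit again.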

Compound 4, half-life: 4.02 h
Beside the measured number, compound 4's estimate is 2.1-fold (0.33 log units) above it; the range from low to high includes it.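

Capping the oxygen, so that hydroxymethyl becomes methoxymethyl, gives an at least 2.1-fold lower number from compound 1 to compound 4 (0.32 log units; beyond the scatter) in this assay. Within the data shown here, this is the first view of this position, since neither compound 2 nor compound 3 carries this group, and it shows that the half-life responds to what sits on that oxygen. The full size of the step cannot be read because compound 1 sits at a limit of the assay: the limit of > 8.53 h in this assay, at which 2 of the 4 values shown sit.

Going by these compounds, with a single replacement at this position, it remains open whether the drop belongs to methyl in particular or to any group on that oxygen. An ethyl or acetyl group there, or a fluorine in place of the hydroxyl, could lower the half-life further or bring it back towards that of compound 1.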